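Acyl exchange at the ring amide of compound 2

The compounds below may be only part of what the source reports. "The series", "measured", "known", "first", "only" and "open" are said of these compounds alone.

Measured compounds:
compound 1 `O=C(Nc1cc(C(F)(F)F)cc(C(F)(F)F)c1)C1CCc2ccccc2N1C(=O)c1ccccc1Cl`: 4700 nM
compound 2 `CCCCCCCCC(=O)N1c2ccccc2CCC1C(=O)Nc1ccccc1C(F)(F)F`: 8330 nM
compound 3 `CCCCCCCCC(=O)N1c2ccccc2CCC1C(=O)Nc1ccccc1O`: 65000 nM

In a functional assay on ACHN cells (Homo sapiens) for cytotoxicity, read by sulforhodamine B assay, with a stated time of 72 h (a higher number here means a weaker inhibitor of growth, a lower number a stronger inhibitor of growth), compound 2 stands second highest of the three numbers; compound 1 lies nearest, within the scatter, and compound 3 furthest, by the step of a 7.8-fold higher number from compound 2 to compound 3 (0.89 log units; beyond the scatter). Compound 4 `O=C(Nc1ccccc1C(F)(F)F)C1CCc2ccccc2N1C(=O)c1ccccc1Cl` differs from compound 2 by 2-chlorophenyl in place of octyl on a carbonyl carbon. Going by the values given here, no measured step isolates this change: compound 1 carries the same 2-chlorophenyl carbonyl but a differently substituted anilide, and its value set beside that of compound 2 lies within the scatter. Among the compounds with values here, the only measured step, a 7.8-fold higher number from compound 2 to compound 3 (0.89 log units; beyond the scatter), concerns the other amide and does not bear on this one. For compound 4 the step of a 1.5-fold lower number from compound 2 to compound 4 (0.18 log units; within the scatter) is therefore expected to stay within the scatter. Compound 4 is estimated at 5500 nM, with a range from 2500 nM to 12000 nM.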

Compound 4, concentration for 50% growth inhibition: 3900 nM
Estimate against measurement, compound 4: 1.4-fold (0.15 log units) above, and the stated range covers the measured number.
By their numbers in this assay, from the lowest: compounds 4, 1 and 2 (each within the scatter of the next, the first and the last beyond it); then compound 3.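

In this assay, going by these compounds alone, the step of a 2.1-fold lower number from compound 2 to compound 4 (0.33 log units; beyond the scatter) is the first measured change at the carbonyl on the ring amide, with 2-chlorophenyl in place of octyl. At this place, on the 2-trifluoromethyl anilide shared by compound 2 and compound 4, the aromatic acyl group gives a modest gain over the straight chain, so the chain is not needed for growth inhibition. No measured evidence on the reason for this step is at hand.

From the compounds shown here alone, whether the gain belongs to the ring or to the chlorine remains open, and a plain phenyl would separate the two. Going by these compounds, how a longer chain or an amine-bearing acyl group would read at this carbonyl is also open.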